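Swapping the butoxy chain for a benzyloxy group

This account rests on a few compounds, and the source may have more. Where it says the series, first, only, none or still open, it means among the compounds named here.

Measured so far:
compound 1, `CCCNC(=O)Nc1cccc2c1CN(C)CC2c1ccccc1`: > 80 mg/kg
compound 2, `CCCCNC(=O)Nc1cccc2c1CN(C)CC2c1ccccc1`: about 40 mg/kg
compound 3, `CCCCOC(=O)Nc1cccc2c1CN(C)CC2c1ccccc1`: 4 mg/kg

Three compounds share one core and differ only in the group hanging off the carbonyl. In a functional assay on the whole organism for inhibition, with Mus musculus as the target (a lower number here means that less compound is needed, a higher number that more compound is needed for the effect), compound 1 reaches only (the limit of > 80 mg/kg in this assay, at which 1 of the 3 values shown sits), which is a limit of the assay and not a number. Compound 3 has the lowest of the two real numbers; its nearest neighbour is compound 2, and the step of a 10-fold lower number from compound 2 to compound 3 (1.00 log units; beyond the scatter) separates them. The step of an at least 20-fold lower number from compound 1 to compound 3 (1.30 log units; beyond the scatter) points the same way.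

Compound 4, `CN1Cc2c(NC(=O)OCc3ccccc3)cccc2C(c2ccccc2)C1`, keeps the carbamate link of compound 3 and changes only the chain: phenyl in place of propyl on a saturated chain carbon bound to an oxygen next to a carbonyl group. For the measured compounds named here, none of the measured steps alters a group at this place while keeping a butoxy link; the only change along a chain, an at least 2.0-fold lower number from compound 1 to compound 2 (0.30 log units; that floor lies within the scatter), is within the scatter. No step beyond the scatter is therefore expected, and the step of no change at the digits printed from compound 3 to compound 4 (within the scatter) is only an estimate. Compound 4 is expected to give about 4 mg/kg, with a range from 1 mg/kg to 16 mg/kg.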

Compound 4, dose for half-maximal effect: about 15 mg/kg
For compound 4 the middle estimate is 3.8-fold (0.57 log units) below the measured one; measured number inside the range.
By their numbers in this assay, from the lowest: compound 3; then compound 4; then compound 2. At a limit, above all of these: compound 1.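

At this place, on a saturated chain carbon bound to an oxygen next to a carbonyl group, the result in this assay shows that the chain itself matters: butoxy to benzyloxy gives a 3.8-fold higher number from compound 3 to compound 4 (0.57 log units; beyond the scatter), the only step shown that alters this group while the carbamate link stays. The link still counts with the new group, since benzyloxy in place of butylamino gives a 2.7-fold lower number from compound 2 to compound 4 (0.43 log units; beyond the scatter), and benzyloxy in place of propylamino gives an at least 5.3-fold lower number from compound 1 to compound 4 (0.72 log units; beyond the scatter). That last step rests on a value for compound 1 that is a limit and not a number: the limit of > 80 mg/kg in this assay, at which 1 of the 4 values shown sits.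

Nothing shown gives a reason for the difference between butoxy and benzyloxy. As far as these compounds go, it also remains open whether a longer chain ending in phenyl, or a cyclohexylmethoxy group, would sit nearer to compound 3 or to compound 4.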